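A few compounds are considered here, and "the series" means these few. Any claim that something is new, unique, unknown or untested is made for them only; others in the source may bear on it.

Compound 1 `CC1=CC[C@H](C(C)(C)NC(=S)NN)CC1` and compound 2 `CC1=CC[C@H](C(C)(C)NC(=S)N/N=C/c2ccc(O)cc2)CC1` share one core and differ in the group hung from the thiourea hydrazine end. In a functional assay on 786-0 cells (Homo sapiens) for inhibition, read by sulforhodamine B assay, with a stated time of 48 h (a higher number here means a weaker inhibitor of growth, a lower number a stronger inhibitor of growth), compound 1 gives only a limit of > 100000 nM. In this assay compound 2 likewise gives only a limit, > 100000 nM. Compound 2 thus stands at the limit of > 100000 nM in this assay, at which 2 of the 2 values shown sit, with no number to set against another. Compound 3 `CC1=CC[C@H](C(C)(C)NC(=S)N/N=C/c2ccc(Cl)cc2)CC1` is compound 2 with chloro in place of hydroxy on an aromatic carbon. No measured step of this kind exists among the shown compounds, so neither direction nor size in this assay can be read from them. Compound 3 is expected to remain near 100000 nM, between 30000 nM and 300000 nM. The estimated step of a number no higher from compound 2 to compound 3 (the limit leaves the size open) is none beyond the usual scatter.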

Compound 3, concentration for 50% growth inhibition: 74900 nM
Estimate against measurement, compound 3: 1.3-fold (0.13 log units) above; measured number inside the range.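

Going by these compounds alone, compound 3 is the first compound here to give a real number in this assay rather than a limit, so the 4-chlorophenyl end brings growth inhibition into measurable range, though only weakly. Chloro in place of hydroxy on an aromatic carbon gives an at least 1.3-fold lower number from compound 2 to compound 3 (0.12 log units; that floor lies within the scatter). That step is only a floor, since the other two compounds give no number: the limit of > 100000 nM in this assay, at which 2 of the 3 values shown sit.

As far as these compounds go, the true size of this step stays open. So does whether an amine or a carboxylic acid at the same ring carbon would give a number.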